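Swapping chloro for nitro: what growth inhibition to expect

The compounds below may be only part of what the source reports. "The series", "measured", "known", "first", "only" and "open" are said of these compounds alone.

Measured so far in a functional assay on NCI-H460 cells (Homo sapiens) for inhibition, read by MTT assay, with a stated time of 24 h, tested at 100 ug/mL (a lower number here means less inhibition of growth, a higher number more inhibition of growth at the concentration tested), are three compounds
compound 1 (`O=C(CCCCC1CCSS1)Nc1cccc2ccccc12`) gives "not active" (no number reported)
compound 2 (`O=C(CCCCC(S)CCS)Nc1ccc(Cl)cc1`) gives 40.9%
compound 3 (`O=C(CCCCC(S)CCS)Nc1cccc(C(F)(F)F)c1`) gives 32.1%

Compound 2 stands level with compound 3: their two numbers lie within the usual scatter of each other, and compound 1 offers no number to set beside them. The next compound, compound 4 (`O=C(CCCCC(S)CCS)Nc1ccc([N+](=O)[O-])cc1`), keeps the structure of compound 2 except for one group, with nitro in place of chloro on an aromatic carbon, para to a large group (nitro in place of chloro on an aromatic carbon). Going by the values given here, no two measured compounds differ in just one place, so the data show no step of this kind. Among the compounds with values here, the only guide is that compound 2 (40.9%) and compound 3 (32.1%) sit within the scatter of each other, so no step beyond the scatter is expected in this assay here. The expected change is a number 2.9 percentage points lower from compound 2 to compound 4 (within the scatter) and stays within the scatter. The estimate for compound 4 (38%) comes with an expected range (22% to 54%).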

Compound 4, percent growth inhibition at one concentration: 39.1%
For compound 4 the middle estimate is 1.1 percentage points below the measured one; the measured number falls inside the stated range.
By their numbers in this assay, from the lowest: compounds 3, 4 and 2 (each within the scatter of the next).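

In this assay, going by these compounds alone, putting nitro in place of chloro on the aromatic carbon para to a large group gives a number 1.8 percentage points lower from compound 2 to compound 4 (within the scatter), the first step in this set that changes one place only. It shows that this position accepts the 3 heavy atoms of nitro, with its 2 hydrogen-bond acceptors, in place of the single chlorine, with no step beyond the scatter at the one concentration tested. No measurement shown here offers an explanation for this result.

As far as these compounds go, whether an amine or a carboxylic acid at this same position would also stay within the scatter remains open. Compound 1 differs from compound 2 in more than one place, so these compounds cannot show which of its structural differences goes with its result.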